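A few compounds are considered here, and "the series" means these few. Any claim that something is new, unique, unknown or untested is made for them only; others in the source may bear on it.

In a functional assay on KBVIN cells (Homo sapiens) for antiproliferative activity, read by sulforhodamine B assay, with a stated time of 3 days (a higher number here means that more compound is needed for the effect, a lower number that less compound is needed), three compounds share one core and differ only in its substituted phenyl group. Compound 1 `CCC1=C(O)c2c(oc(-c3ccc(C)cc3)cc2=O)C(CC)(CC)C1=O` gives 0.08 uM, compound 2 `CCC1=C(O)c2c(oc(-c3cc(C)c(C)cc3C)cc2=O)C(CC)(CC)C1=O` gives 4.37 uM, and compound 3 `CCC1=C(O)c2c(oc(-c3ccc(OC)c(Cl)c3)cc2=O)C(CC)(CC)C1=O` gives 1.37 uM, the second highest of the three numbers. Compound 4 `CCC1=C(O)c2c(oc(-c3ccc(F)c(C)c3)cc2=O)C(CC)(CC)C1=O` is unmeasured and carries 4-fluoro-3-methylphenyl in place of 3-chloro-4-methoxyphenyl on an aromatic carbon. Among the compounds with values here, three steps bear on this change: the large 55-fold higher number from compound 1 to compound 2 (1.74 log units; beyond the scatter), the large 17-fold higher number from compound 1 to compound 3 (1.23 log units; beyond the scatter), and the modest 3.2-fold lower number from compound 2 to compound 3 (0.50 log units; beyond the scatter). Each lies beyond the scatter, so a real step is expected, though none isolates the new group. The expected result is a 2.7-fold lower number from compound 3 to compound 4 (0.44 log units; beyond the scatter), a modest move toward compound 1. Compound 4 is estimated at 0.5 uM, with an expected range of 0.12 uM to 2 uM.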

Compound 4, concentration for half-maximal effect: 1.62 uM
Beside the measured number, compound 4's estimate is 3.2-fold (0.51 log units) below it, and the stated range covers the measured number.
By their numbers in this assay, from the lowest: compound 1; then compounds 3 and 4 (each within the scatter of the next); then compound 2.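

In this assay the exchange at this position gives a 1.2-fold higher number from compound 3 to compound 4 (0.07 log units; within the scatter) and so leaves the number unchanged within the scatter. Although 4-fluoro-3-methylphenyl keeps a methyl group on the phenyl ring, the result is a 20-fold higher number from compound 1 to compound 4 (1.31 log units; beyond the scatter) and only 4-methylphenyl of the four groups gives the low number, while a 2.7-fold lower number from compound 2 to compound 4 (0.43 log units; beyond the scatter) keeps 2,4,5-trimethylphenyl apart from the other two. Nothing shown here gives a cause for these steps.

The compounds shown leave open how a 4-fluorophenyl or a 4-aminophenyl group at this position would compare with compound 1.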